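The source may report more compounds than this note shows. Statements on the series, on what has been measured and on what is new or still open speak of the compounds shown alone.

Compound 1 `Cc1ccc(C(=O)Nc2cc(-c3ccccc3)nn2-c2ccccc2)cc1`: 40 nM
Compound 2 `O=C(Nc1cc(-c2ccccc2)nn1-c1ccccc1)c1cccc(Cl)c1`: 200 nM
Compound 3 `O=C(Nc1cc(-c2ccccc2)nn1-c1ccccc1)c1ccccc1F`: 100 nM

In an assay on isolated protein with metabotropic glutamate receptor 5 (Rattus norvegicus) as the target (on this read-out lower numbers stand for an effect already at smaller amounts and higher numbers for an effect only at larger amounts of compound), compound 1 stands with the lowest of the three numbers. Both neighbours sit beyond the scatter from it, as the steps of a 2.5-fold higher number from compound 1 to compound 3 (0.40 log units; beyond the scatter) and a 5.0-fold higher number from compound 1 to compound 2 (0.70 log units; beyond the scatter) show, while the gap a 2.0-fold lower number from compound 2 to compound 3 (0.30 log units; within the scatter) lies within the scatter. Compound 4 `O=C(Nc1cc(-c2ccccc2)nn1-c1ccccc1)c1ccccc1O` differs from compound 1 by 2-hydroxyphenyl in place of 4-methylphenyl on a carbonyl carbon. The two measured steps that bear on this step both replace the aryl on the carbonyl carbon and both raised the number modestly. A modest upward step is therefore expected for compound 4 as well, a 3.8-fold higher number from compound 1 to compound 4 (0.57 log units; beyond the scatter). In this assay compound 4 is estimated at 150 nM, with a range from 50 nM to 600 nM.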

Compound 4, half-maximal effective concentration: > 10000 nM
Compound 4 gave a limit, no number; the forecaster's own chance of this, stated with the estimate: 5%; middle value at least 66-fold (1.82 log units) away from the limit.
By their numbers in this assay, from the lowest: compound 1; then compounds 3 and 2 (each within the scatter of the next). At a limit, above all of these: compound 4.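

Compound 4 gives only a limit, not a number: the limit of > 10000 nM in this assay, at which 1 of the 4 values shown sits.

For the compounds shown here, the single change of hydroxy in place of fluoro on an aromatic carbon gives an at least 100-fold higher number from compound 3 to compound 4 (2.00 log units; beyond the scatter), and the other two steps read an at least 250-fold higher number from compound 1 to compound 4 (2.39 log units; beyond the scatter) and an at least 50-fold higher number from compound 2 to compound 4 (1.69 log units; beyond the scatter). The earlier replacements of the aryl on the carbonyl carbon had shown only modest steps, so this place proves far less forgiving than compounds 1, 2 and 3 suggested.

The compounds shown leave open whether 2-methoxyphenyl or 2-aminophenyl in this place would follow compound 3 or compound 4.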